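This account rests on a few compounds, and the source may have more. Where it says the series, first, only, none or still open, it means among the compounds named here.

Working notes on the series, measured so far in a functional assay on A549 cells (Homo sapiens) for inhibition, read by CCK-8 assay, with a stated time of 72 h, tested at 1 uM; on this read-out higher numbers stand for more inhibition of growth at the one concentration tested and lower numbers for less inhibition of growth:

- compound 1 `Cc1cccc(NC(=O)C2(C(=O)Nc3ccc(Nc4ncc5cc(C(=O)N(C)C)n(C6CCCC6)c5n4)cc3)CC2)c1` gives 35.2%
- compound 2 `CN(C)C(=O)c1cc2cnc(Nc3ccc(NC(=O)C4(C(=O)Nc5ccccc5F)CC4)cc3)nc2n1C1CCCC1` gives 79.1%
- compound 3 `COC(=O)c1cccc(NC(=O)C2(C(=O)Nc3ccc(Nc4ncc5cc(C(=O)N(C)C)n(C6CCCC6)c5n4)cc3)CC2)c1` gives 10.5%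

Compound 3 holds the lowest of the three numbers, and both other compounds lie beyond the scatter from it. The next compound to be read is compound 4 `CN(C)C(=O)c1cc2cnc(Nc3ccc(NC(=O)C4(C(=O)Nc5ccc(O)cc5)CC4)cc3)nc2n1C1CCCC1`. The change is 4-hydroxyphenyl in place of 3-(methoxycarbonyl)phenyl on an amide-type nitrogen.

All three measured steps alter the aryl group on this nitrogen. The data show a number 43.9 percentage points higher from compound 1 to compound 2 (beyond the scatter), a number 24.7 percentage points lower from compound 1 to compound 3 (beyond the scatter) and a number 68.6 percentage points lower from compound 2 to compound 3 (beyond the scatter). Changes here have therefore moved the number by modest to large amounts, and none of the steps fell within the scatter. Going by the values given here, no measured compound carries a hydroxy group, so the size of the step remains uncertain.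

The departing group belongs to the lowest compound, and a rise is expected, since compound 1 35.2% and compound 2 79.1% both stand higher with other aryl groups. A modest to large step is expected, estimated as a number 34.5 percentage points higher from compound 3 to compound 4 (beyond the scatter). For compound 4 the expected value is 45%, with an estimated range from 20% to 75%.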

Compound 4, percent growth inhibition at one concentration: 93.6%
Compound 4: the middle estimate sits 48.6 percentage points below what was measured, outside the stated range (above it).
By their numbers in this assay, from the lowest: compound 3; then compound 1; then compound 2; then compound 4.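

In this assay, the aryl group on this amide-type nitrogen now reaches a new top for the series: 4-hydroxyphenyl gives a number 83.1 percentage points higher from compound 3 to compound 4 (beyond the scatter), a number 58.4 percentage points higher from compound 1 to compound 4 (beyond the scatter) and a number 14.5 percentage points higher from compound 2 to compound 4 (beyond the scatter), so compound 4 stands above each of the other compounds shown. Going by these compounds alone, the spread at this one position is therefore wider than the earlier compounds showed, and the first aryl group here to carry a hydroxy group sits at its upper end, although compound 2, without a hydroxy group, also stands above compound 1 and compound 3. Nothing at hand bears on the reason for this rise.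

As far as these compounds go, whether the high number follows the hydroxy group itself or its place on the ring stays open, and a 3-hydroxyphenyl or a 4-methoxyphenyl group on this nitrogen would separate the two readings. From the compounds shown here alone, with one concentration only, it also stays open how compound 2 and compound 4 compare over a range of concentrations, and whether a 4-aminophenyl or 4-carboxyphenyl group would hold the number.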